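The source may report more compounds than this note shows. Statements on the series, on what has been measured and on what is new or still open speak of the compounds shown alone.

Measured compounds:
compound 1 `CNC(=O)c1cc(-c2cnc(NCc3c(F)ccc4c3CCO4)c3cn[nH]c(=O)c23)n(C)n1` — < 3 mL.min-1.g-1
compound 2 `O=C1CC2(CC2)CN1c1cnc(NCc2c(F)ccc3c2CCO3)n2cnnc12` — < 3 mL.min-1.g-1
compound 3 `O=C(Nc1cnc(NCc2c(F)ccc3c2CCO3)n2cnnc12)c1cccnc1` — < 3 mL.min-1.g-1

In an ADME assay on microsomes from liver (Homo sapiens) for metabolic stability, read by LC-MS, using NADPH, with stated times of 5 min and 30 min, tested at 1 uM (on this read-out higher numbers stand for fast clearance and lower numbers for slow clearance), compound 1 gives < 3 mL.min-1.g-1, and this is a limit of the assay rather than a number. Compound 2 likewise sits at a limit. Compound 3 also sits at a limit. All three values therefore coincide at the limit of < 3 mL.min-1.g-1 in this assay, at which 3 of the 3 values shown sit, and compound 1 stands at the same limit as the other two, with no ordering possible among them.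

Within the data shown here, the one step between measured compounds, a step that the two limits leave unreadable from compound 2 to compound 3, cannot be sized, since both ends are limits.

Compound 4 `Cc1nn(C)cc1-c1cnc(NCc2c(F)ccc3c2CCO3)c2cn[nH]c(=O)c12` differs from compound 1 by 1,3-dimethyl-1H-pyrazol-4-yl in place of 1-methyl-3-(methylcarbamoyl)-1H-pyrazol-5-yl on an aromatic carbon. Neither measured step touches this part of the structure, and the only step shown is unreadable, so no measured step bears on the change. The evidence at hand is simply that compound 1, and every other compound here, rests at the limit.

Compound 4 is therefore expected to stay near that limit, with a step of a number no lower from compound 1 to compound 4 (the limit leaves the size open) from compound 1 in this assay that is not expected to exceed the scatter. The estimate for compound 4 is 3 mL.min-1.g-1, with a likely range from 1 mL.min-1.g-1 to 9 mL.min-1.g-1.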

Compound 4, intrinsic clearance in microsomes: 27 mL.min-1.g-1
Compound 4: the middle estimate sits 9.0-fold (0.95 log units) below what was measured; measured number outside the range, above it.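

On the core of compound 1, the aromatic carbon that carries the pyrazole turns out to be a place where the read-out can move: in this assay, putting 1,3-dimethyl-1H-pyrazol-4-yl in place of 1-methyl-3-(methylcarbamoyl)-1H-pyrazol-5-yl gives an at least 9.0-fold higher number from compound 1 to compound 4 (0.95 log units; beyond the scatter). Compound 1 sits at a limit of the assay, so this step has a floor and no upper bound. The earlier compounds could not show such a change, and compound 4 is the only one shown that stands clear of the value they share: the limit of < 3 mL.min-1.g-1 in this assay, at which 3 of the 4 values shown sit.

The change does more than one thing at once, removing the methylcarbamoyl group, which carries the only hydrogen-bond donor of the leaving group, and moving the pyrazole's point of attachment from its 5-position to its 4-position, and the compounds shown do not separate these two parts. Also open, as far as these compounds go, is whether a carboxylic acid or a dimethylamino group in place of the methylcarbamoyl group, on the 1-methyl-1H-pyrazol-5-yl, would keep the value at the limit.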